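The source may hold more compounds than are shown below. What is called first, only, known or untested is meant among the compounds shown, and "the series" means these compounds.

Working notes on a short series tested in an assay on membranes from CHO cells for displacement of a labelled ligand from adenosine receptor A1 (Homo sapiens), read by scintillation counting, with a stated time of 60 min, tested at 1 uM; a higher number here means more inhibition at the concentration tested (going by the name of the read-out), a lower number less inhibition. Among the measured compounds shown here, compound 1 `CCOC(=O)C1=C(C)N(C)C(=O)NC1c1cccs1` and compound 2 `COC(=O)C1=C(C)N(C)C(=O)NC1c1ccsc1` differ from each other in more than one place, so no single step is drawn between them; what their numbers show is that in this assay compound 1 gives 1%, while in this assay compound 2 gives 24%. For the measured compounds named here, compound 2 thus stands highest of the two numbers measured so far, with compound 1 as its nearest neighbour at a gap beyond the usual scatter. Compound 3 `CCOC(=O)C1=C(C)N(C)C(=O)NC1c1ccsc1` has not yet been measured in this assay. It differs from compound 2 by methyl in place of hydrogen on a saturated chain carbon bound to an oxygen next to a carbonyl group. Compound 1 also carries the ethoxycarbonyl group and gives 1%, but it differs from compound 2 in a second place as well, so that number does not isolate this change. For the present step no movement beyond the scatter is expected; the estimated step is a number 9 percentage points lower from compound 2 to compound 3 (within the scatter), a small downward drift only. Compound 3 is accordingly expected to give about 15% in this assay, with a range from 0% to 35%.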

Compound 3, a percentage reported as inhibition, at one concentration (the size of the read-out at that concentration, not a potency): 32%
Beside the measured number, compound 3's estimate is 17 percentage points below it; low and high end bracket the measured number.
By their numbers in this assay, from the lowest: compound 1; then compounds 2 and 3 (each within the scatter of the next).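

Methyl in place of hydrogen on a saturated chain carbon bound to an oxygen next to a carbonyl group, which turns methoxycarbonyl into ethoxycarbonyl, gives in this assay a number 8 percentage points higher from compound 2 to compound 3 (within the scatter) and so does not separate the two compounds on the thiophen-3-yl side. With the ethoxycarbonyl group held constant, thiophen-3-yl in place of thiophen-2-yl on a saturated ring carbon gives a number 31 percentage points higher from compound 1 to compound 3 (beyond the scatter) as a step of its own, so the large gap between the thiophene isomers no longer rests on a pair that differs in two places. No measured information bears on why either step has the size it has.

Among the compounds shown here, whether methoxycarbonyl and ethoxycarbonyl also read alike on the thiophen-2-yl side remains open, as the single step at this position is read on the thiophen-3-yl side only. Also open is how the read-out in this assay responds to a longer chain such as propoxycarbonyl or to a carboxylic acid at this place, and the readings at one concentration give no potency for any of these compounds.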